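Replacing 3-nitrophenyl with pyridin-4-yl on the shared core

The compounds below may be only part of what the source reports. "The series", "measured", "known", "first", "only" and "open" are said of these compounds alone.

Going by the values given here, in a functional assay on FM3A cells (Mus musculus) for antiproliferative activity (on this read-out lower numbers stand for stronger inhibition and higher numbers for weaker inhibition), compound 2 (`COc1cc(C(=O)c2sc(-c3cccc([N+](=O)[O-])c3)cc2N)cc(OC)c1OC`) gives 17 nM, the lower of the two numbers so far, while compound 1 (`COc1cc(C(=O)c2sc(-c3ccc(Br)cc3)cc2N)cc(OC)c1OC`) gives 150 nM. Compound 3 (`COc1cc(C(=O)c2sc(-c3ccncc3)cc2N)cc(OC)c1OC`) awaits measurement. It carries pyridin-4-yl in place of 3-nitrophenyl on an aromatic carbon. Among the compounds with values here, only one measured step bears on this carbon, an 8.8-fold lower number from compound 1 to compound 2 (0.95 log units; beyond the scatter), a modest one, and it involves no ring with a hetero atom. A step of comparable size towards weaker inhibition is therefore expected, with the estimate being a 5.9-fold higher number from compound 2 to compound 3 (0.77 log units; beyond the scatter). For compound 3 the estimated value is 100 nM, within a range of 25 nM to 500 nM.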

Compound 3, half-maximal inhibitory concentration: 150 nM
Beside the measured number, compound 3's estimate is 1.5-fold (0.18 log units) below it, and the stated range covers the measured number.
By their numbers in this assay, from the lowest: compound 2; then compounds 1 and 3 (each within the scatter of the next).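

In this assay, moving to pyridin-4-yl on this carbon next to the ring sulfur gives an 8.8-fold higher number from compound 2 to compound 3 (0.95 log units; beyond the scatter) and so loses the advantage seen with 3-nitrophenyl. Set against 4-bromophenyl, the same group gives no change at the digits printed from compound 1 to compound 3 (within the scatter) and thus two quite different aromatic groups read alike, with only 3-nitrophenyl standing apart among these three compounds. Nothing available here explains this result.

As far as these compounds go, it remains open whether the low number depends on the nitro group itself or on where it sits, as a 4-nitrophenyl or 3-bromophenyl group would show. Where unsubstituted phenyl or pyridin-3-yl would fall is also unknown.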